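Trimming the pyrrolidine substituent in a Chk2 series

A few compounds are considered here, and "the series" means these few. Any claim that something is new, unique, unknown or untested is made for them only; others in the source may bear on it.

Compound 1 `COc1cc2nc(-c3ccccc3O)nc(N[C@H]3CCNC3)c2cc1OC`: in an assay on isolated protein for inhibition of serine/threonine-protein kinase Chk2 (Homo sapiens) (on this read-out lower numbers stand for stronger inhibition and higher numbers for weaker inhibition), compound 1 gives 28 nM.
Compound 3 `COCCOc1cc2nc(-c3cc(F)ccc3O)nc(N[C@H]3CCNC3)c2cc1OC`: in this assay compound 3 gives 30 nM.
Compound 2 `CC(C)(O)[C@H]1C[C@H](Nc2nc(-c3cc(F)ccc3O)nc3ccccc23)CN1`: in this assay compound 2 gives 460 nM.

Among the three measured compounds, compound 2 stands at the highest number in this assay, and the gap to each of the other two lies beyond the usual scatter. Compound 2 differs from compound 1 and compound 3 in more than one place, so the data do not separate what each difference contributes.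

Compound 4 `OC[C@H]1C[C@H](Nc2nc(-c3cc(F)ccc3O)nc3ccccc23)CN1` has not been measured. It follows from compound 2 by a single change: hydroxymethyl in place of 1-hydroxy-1-methylethyl on a saturated ring carbon. The 5-(1-hydroxy-1-methylethyl)pyrrolidin-3-yl group becomes 5-(hydroxymethyl)pyrrolidin-3-yl, with the donor and acceptor count unchanged.

Going by the values given here, no measured pair isolates this change, so the direction is uncertain. The smaller group brings compound 4 closer in shape to the unsubstituted pyrrolidin-3-yl of compound 1 and compound 3, which give the lower numbers, so a modest step toward stronger inhibition is expected: a 1.8-fold lower number from compound 2 to compound 4 (0.26 log units; within the scatter). Compound 4 is estimated at 250 nM in this assay, with a range from 80 nM to 800 nM.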

Compound 4, half-maximal inhibitory concentration: 81 nM
Compound 4: middle estimate off by 3.1-fold (0.49 log units), on the high side; measured number inside the range.
By their numbers in this assay, from the lowest: compounds 1 and 3 (each within the scatter of the next); then compound 4; then compound 2.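

The step shows that this saturated ring carbon, next to the ring nitrogen, is sensitive to the size of what it carries: in this assay, hydroxymethyl in place of 1-hydroxy-1-methylethyl gives a 5.7-fold lower number from compound 2 to compound 4 (0.75 log units; beyond the scatter). Going by these compounds alone, this is the first comparison here that rests on a single difference, and the earlier compounds could not show what the group at this carbon contributes on its own. The change takes the group from 4 heavy atoms to 2 while the hydroxyl stays and each side keeps 1 hydrogen-bond donor and 1 hydrogen-bond acceptor, and nothing measured here explains why the number moves.

Compound 4 still differs from compound 1 and compound 3 in more than one place, so the data do not say how much of the difference in their numbers belongs to this carbon and how much to the other differences. Also open, as far as these compounds go, is whether the hydroxyl matters at all, which a plain methyl at this carbon would address, and how an aminomethyl group or a carboxylic acid in the same place would read in this assay.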